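Working notes: isopropyl to 3-cyanophenyl from compound 1

The source may report more compounds than this note shows. Statements on the series, on what has been measured and on what is new or still open speak of the compounds shown alone.

Measured so far in a functional assay on T98G cells (Homo sapiens) for inhibition, read by MTT assay, with a stated time of 72 h; a lower number here means a stronger inhibitor, a higher number a weaker inhibitor:
- compound 1 `CC(C)NC(=S)NC1CC(C)(C)Oc2ccc(Cl)cc21`: 91000 nM
- compound 2 `CC(C)NC(=O)NC1CC(C)(C)Oc2ccc(Cl)cc21`: > 100000 nM (a limit)
- compound 3 `CCNC(=O)NC1CC(C)(C)Oc2ccc(Cl)cc21`: "not determined" (no result reported)

Among the measured compounds shown here, compound 1 carries the only actual number in this small set. Compound 2 has only a limit, and compound 3 has no result, so compound 1 cannot be ranked firmly against either.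

The next compound is compound 4 `CC1(C)CC(NC(=S)Nc2cccc(C#N)c2)c2cc(Cl)ccc2O1`, with 3-cyanophenyl in place of isopropyl on an amide-type nitrogen.

For the measured compounds named here, the single measured step is an at least 1.0-fold higher number from compound 1 to compound 2 (0.04 log units; that floor lies within the scatter). That step keeps isopropyl in place, and its floor lies within the scatter. Compound 2 sits at the limit of > 100000 nM in this assay, at which 1 of the 3 values shown sits. Going by the values given here, no measured step covers the site that changes in compound 4, so the size of the coming step is poorly constrained and the range must stay wide.

Compound 1 at 91000 nM leaves little room for a higher number to be read in this assay, so a moderate move to a lower number is expected. The expected step is a 3.6-fold lower number from compound 1 to compound 4 (0.56 log units; beyond the scatter). The estimated half-maximal inhibitory concentration for compound 4 is 25000 nM, with an expected range of 6000 nM to 90000 nM.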

Compound 4, half-maximal inhibitory concentration: 10000 nM
Estimate against measurement, compound 4: 2.5-fold (0.40 log units) above; measured number inside the range.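

In this assay, the substituent on the amide-type nitrogen proves able to move the read-out: 3-cyanophenyl in place of isopropyl gives a 9.1-fold lower number from compound 1 to compound 4 (0.96 log units; beyond the scatter). Among the compounds shown here, this is the first measured change at this site, and the first step printed as beyond the scatter, since the only earlier step, which changed thiocarbonyl to carbonyl and kept isopropyl, has a floor that lies within it. The entering group brings in a six-membered aromatic ring and a nitrile together, and this single step does not separate the contribution of the ring from that of the nitrile.

Still open, on these data alone, is whether an unsubstituted phenyl would keep the step, and how a methoxy group or a carboxylic acid would read in place of the nitrile on that ring. Also open, as far as these compounds go, is how a carbonyl in place of the thiocarbonyl would read with 3-cyanophenyl on the nitrogen, and compound 2 offers only a limit as a guide: the limit of > 100000 nM in this assay, at which 1 of the 4 values shown sits.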